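The compounds below may be only part of what the source reports. "The series", "measured", "known", "first", "only" and "open" are said of these compounds alone.

Measured compounds:
compound 1 `Fc1cccc(-c2nc(Nc3ccccc3)c3cc(F)ccc3n2)c1` — 49700 nM
compound 2 `Fc1cccc(-c2nc(Nc3cccc(Br)c3)c3cc(F)ccc3n2)c1` — > 50000 nM

In a functional assay on COLO 205 cells (Homo sapiens) for cytotoxicity, read by MTT assay, with a stated time of 48 h (on this read-out higher numbers stand for weaker inhibition and lower numbers for stronger inhibition), compound 1 gives 49700 nM. Compound 2 gives > 50000 nM, which is a limit of the assay and not a number; compound 2 thus sits at the limit of > 50000 nM in this assay, at which 1 of the 2 values shown sits. Compound 3 `Nc1cccc(Nc2nc(-c3cccc(F)c3)nc3ccc(F)cc23)c1` differs from compound 2 by amino in place of bromo on an aromatic carbon. Going by the values given here, the one measured step, a number no lower from compound 1 to compound 2 (the limit leaves the size open), touches the same aromatic carbon, but its size cannot be read, and both values sit at or near the limit. Compound 3 is therefore expected to stay at that weak level, with an expected step of an at least 1.2-fold lower number from compound 2 to compound 3 (0.09 log units; that floor lies within the scatter) not beyond the scatter. Compound 3 is estimated at 40000 nM, between 10000 nM and 150000 nM.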

Compound 3, half-maximal inhibitory concentration: > 50000 nM
Compound 3 ended at the assay's limit; the forecaster's own chance of this, stated with the estimate: 55%; middle value at least 1.2-fold (0.09 log units) away from the limit.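

In this assay compound 3 gives > 50000 nM, which is a limit of the assay and not a number. With amino as well as bromo on this aromatic carbon, neither the donor-bearing 3-aminophenyl nor 3-bromophenyl yields a number, and the steps linking compound 1, compound 2 and compound 3 cannot be read. The values now gather at one end of the scale: the limit of > 50000 nM in this assay, at which 2 of the 3 values shown sit.

Amino in place of hydrogen on that carbon gives a number no lower from compound 1 to compound 3 (the limit leaves the size open); whether a hydroxyl, a methoxy or a carboxylic acid on that carbon would give a number in this assay stays open. So does whether a change elsewhere on the shared core would.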